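Extending a Methyl to Pentyl: Cytotoxicity Expected Largely Unchanged

The source may report more compounds than this note shows. Statements on the series, on what has been measured and on what is new or still open speak of the compounds shown alone.

Measured compounds:
compound 1 `O=C1O[C@H]([C@@H](O)Cn2cc(-c3cc(C(F)(F)F)cc(C(F)(F)F)c3)nn2)C(OCc2ccccc2)=C1OCc1ccccc1` gives 80700 nM
compound 2 `Cc1ccc(-c2cn(C/C=C3\OC(=O)C(OCc4ccccc4)=C3OCc3ccccc3)nn2)cc1` gives > 100000 nM
compound 3 `O=C1O[C@H]([C@@H](O)Cn2cc(-c3cccc(O)c3)nn2)C(OCc2ccccc2)=C1OCc1ccccc1` gives 39000 nM

All three were tested in an ADME assay on HFF cells (Homo sapiens) for cytotoxicity, read by MTT assay, with a stated time of 72 h (on this read-out higher numbers stand for weaker inhibition and lower numbers for stronger inhibition), a measure of how much of each compound is needed to harm a human skin cell line. Compound 1 and compound 3 both come out as weak inhibitors of cell viability, with compound 3 reaching its effect at a somewhat lower concentration than compound 1, though both sit in the high range. Compound 2 stands apart: its result is a limit of the assay rather than a number, as the limit of > 100000 nM in this assay, at which 1 of the 3 values shown sits, shows, meaning no inhibition was detected up to the highest concentration tested.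

Compound 4 `CCCCCc1ccc(-c2cn(C/C=C3\OC(=O)C(OCc4ccccc4)=C3OCc3ccccc3)nn2)cc1` has not yet been measured. It differs from compound 2 in a single spot: butyl in place of hydrogen on a saturated chain carbon bound to an aromatic carbon. Put simply, the methyl group on the outer benzene ring grows into a pentyl chain, while the rest of the molecule is identical.

Going by the values given here, with no measured pair showing what such a chain extension does in this assay, the expectation rests on compound 2 alone. Since compound 2 reached only the assay limit, compound 4 is expected to stay weak as well, with a step from compound 2 to compound 4 of an at least 1.2-fold lower number from compound 2 to compound 4 (0.09 log units; that floor lies within the scatter), which may be none beyond the scatter. Compound 4 is thus estimated at 80000 nM, within a range from 30000 nM to 200000 nM.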

Compound 4, half-maximal inhibitory concentration: > 100000 nM
Compound 4 was reported as a limit (the forecaster's own chance of this, stated with the estimate: 50%); middle value at least 1.2-fold (0.09 log units) away from the limit.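

Compound 4, like compound 2, was reported only as a limit in this assay, and the step between the two cannot be read: the limit of > 100000 nM in this assay, at which 2 of the 4 values shown sit.

The compounds shown leave open whether going from methyl to pentyl changes the harm done to these cells at all, and if it does, in which direction and by how much.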